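A few compounds are considered here, and "the series" means these few. Any claim that something is new, unique, unknown or untested is made for them only; others in the source may bear on it.

Working notes on the series. Compound 1 `CC(C)(C)c1ccc(C(=O)N2CCC3(CC2)C(=O)N(CC(=O)N2CCC(CCO)CC2)CN3c2ccccc2)cc1` carries a tert-butylphenyl amide on the shared core and gives, in an assay on HEK293 cells for displacement of a labelled ligand from NPC1-like intracellular cholesterol transporter 1 (Homo sapiens) (on this read-out higher numbers stand for weaker inhibition and lower numbers for stronger inhibition), a value of 2600 nM. Among the compounds with values here, compound 3 `CC(C)(C)c1ccc(C(=O)N2CCC3(CC2)C(=O)N(CC(=O)N2CCN(S(C)(=O)=O)CC2)CN3c2ccccc2)cc1` differs from compound 1 only at the terminal amide; in this assay compound 3 gives 19000 nM, and the step of a 7.3-fold higher number from compound 1 to compound 3 (0.86 log units; beyond the scatter) is the only measured step in the set. Compound 2 `CCc1nn(CC)c(C2CCN(C(=O)CN3CN(c4ccccc4)C4(CCN(C(=O)c5ccc(C6CCCCC6)cc5)CC4)C3=O)CC2)c1C` carries a cyclohexylphenyl amide and a substituted piperidine at the terminal amide; for compound 2 the result in this assay is "not determined" (no result reported), so no single number is available and it stands nowhere on the numbers shown. Compound 4 `O=C(CN1CN(c2ccccc2)C2(CCN(C(=O)c3ccc(C4CCCCC4)cc3)CC2)C1=O)N1CCCCC1` is the same as compound 2 except for one change: hydrogen in place of 1,3-diethyl-4-methyl-1H-pyrazol-5-yl on a saturated ring carbon. Within the data shown here, no measured step covers this change, and no measured step covers the cyclohexylphenyl amide either; the one step in the set, from a hydroxyethylpiperidine to a methylsulfonylpiperazine on the carbonyl carbon, shows that changes at the terminal amide move this assay by a modest amount. The step from compound 2 to compound 4 therefore cannot be sized from a parent value, and the expectation for compound 4 rests on compound 1 and compound 3 alone. Compound 4 is expected to give about 3000 nM in this assay, within a range from 600 nM to 15000 nM.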

Compound 4, half-maximal inhibitory concentration: 1100 nM
Estimate against measurement, compound 4: 2.7-fold (0.44 log units) above; measured number inside the range.
By their numbers in this assay, from the lowest: compound 4; then compound 1; then compound 3.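

No new step can be read from compound 4, as compound 2 has no single number in this assay. The compounds shown leave open how the 1,3-diethyl-4-methyl-1H-pyrazol-5-yl group and the cyclohexylphenyl amide each bear on this assay. No evidence on hand bears on this result.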